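Swapping methyl for trifluoromethyl on the shared core

The source may report more compounds than this note shows. Statements on the series, on what has been measured and on what is new or still open speak of the compounds shown alone.

Compound 1 `CN(C(=O)NC(=O)c1ccc(C(F)(F)F)cc1)c1nc(C(F)(F)F)c(C(=O)N/N=C/c2cc(C(F)(F)F)cc(C(F)(F)F)c2)s1`: 5.78 ug/mL
Compound 2 `Cc1nc(N(C)C(=O)NC(=O)c2c(F)cccc2F)sc1C(=O)N/N=C/c1cc(C(F)(F)F)cc(C(F)(F)F)c1`: 12.2 ug/mL

In a functional assay on HeLa cells (Homo sapiens) for inhibition, read by MTT assay, with a stated time of 72 h (a lower number here means a stronger inhibitor, a higher number a weaker inhibitor), compound 2 gives 12.2 ug/mL, the higher of the two numbers measured, and compound 1 gives a lower number, a gap beyond the usual scatter. Compound 3 `CN(C(=O)NC(=O)c1c(F)cccc1F)c1nc(C(F)(F)F)c(C(=O)N/N=C/c2cc(C(F)(F)F)cc(C(F)(F)F)c2)s1` keeps the core of compound 2 and changes one place: trifluoromethyl in place of methyl on an aromatic carbon. Among the measured compounds shown here, no single-point step between measured compounds is known, so the size of this change cannot be read from the data. Compound 3 is expected to give a modest step down from compound 2, a 1.5-fold lower number from compound 2 to compound 3 (0.18 log units; within the scatter), with an estimate of 8 ug/mL and a range from 3 ug/mL to 20 ug/mL.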

Compound 3, half-maximal inhibitory concentration: 5.62 ug/mL
Beside the measured number, compound 3's estimate is 1.4-fold (0.15 log units) above it, within the range that was stated.
By their numbers in this assay, from the lowest: compounds 3 and 1 (each within the scatter of the next); then compound 2.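

In this assay trifluoromethyl in place of methyl on the aromatic carbon next to the ring nitrogen gives a 2.2-fold lower number from compound 2 to compound 3 (0.34 log units; beyond the scatter) as the first one-place step read at this position. In another place, 2,6-difluorophenyl in place of 4-(trifluoromethyl)phenyl on a carbonyl carbon gives a 1.0-fold lower number from compound 1 to compound 3 (0.01 log units; within the scatter) and so separates the two compounds by no real difference. No measurement here gives a reason for either step.

Going by these compounds, whether an ethyl chain, a chlorine atom or an amine at this position would also lower the number stays open. So does whether the methyl-to-trifluoromethyl step has the same size with the 4-(trifluoromethyl)phenyl group of compound 1.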